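Chloro for methyl against a cytotoxicity ceiling

The compounds below may be only part of what the source reports. "The series", "measured", "known", "first", "only" and "open" are said of these compounds alone.

Compound 1 `Cc1ccc(NC(=O)c2cccc(/C=C3\CC(=O)N(c4ccccc4)C3=O)c2)cc1` is read in an ADME assay on NCM460 cells (Homo sapiens) for cytotoxicity, read by MTT assay, with a stated time of 72 h; a lower number here means a stronger inhibitor, a higher number a weaker inhibitor. In this assay compound 1 gives only a limit, > 100000 nM, not a number. Compound 2 `CCCCCN1C(=O)C/C(=C\c2cccc(C(=O)NCCCC)c2)C1=O` likewise gives a limit, > 100000 nM. Compound 3 `CCCCCN1C(=O)C/C(=C\c2cccc(C(=O)Nc3ccc(OC)cc3)c2)C1=O` also gives a limit, > 100000 nM. Among the measured compounds shown here, the single one-point step, a step that the two limits leave unreadable from compound 2 to compound 3, stays unreadable since (the limit of > 100000 nM in this assay, at which 3 of the 3 values shown sit). Compound 4 `O=C(Nc1ccc(Cl)cc1)c1cccc(/C=C2\CC(=O)N(c3ccccc3)C2=O)c1` differs from compound 1 by chloro in place of methyl on an aromatic carbon, sitting on an aromatic carbon of a six-membered aromatic ring of carbon only, para to a large group. For the measured compounds named here, no measured step bears on a chloro-for-methyl swap, and every value so far sits at the limit. Compound 4 is therefore expected to give 150000 nM, most likely again reported as a limit rather than a number. For compound 4 the estimated range runs from 50000 nM to 500000 nM. The expected step that the limit leaves unreadable from compound 1 to compound 4 is none beyond the scatter.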

Compound 4, half-maximal inhibitory concentration: > 100000 nM
Compound 4 ended at the assay's limit; the forecaster's own chance of this, stated with the estimate: 85%; the middle value is on the limit's open side.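

Compound 1 and compound 4 each give only a limit in this assay, so no step can be read for chloro in place of methyl: the limit of > 100000 nM in this assay, at which 4 of the 4 values shown sit.

The compounds shown leave open whether any change to the shared core gives a measurable value in this assay.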